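Ester to acid on the biphenyl: an untested change

This account rests on a few compounds, and the source may have more. Where it says the series, first, only, none or still open, it means among the compounds named here.

Measured compounds:
- Compound 1, `COC(=O)c1c(F)cccc1-c1ccc(CCc2ncc(CC(C)(C)C)n2Cc2ccc(C(=O)O)cc2)cc1`: 5 nM
- Compound 2, `COC(=O)c1c(F)cccc1-c1ccc(CCc2ncc(CC(C)(C)C)n2CCOc2cccc(O)c2)cc1`: 25 nM
- Compound 3, `COC(=O)c1c(F)cccc1-c1ccc(CCc2ncc(CC(C)(C)C)n2CCNS(C)(=O)=O)cc1`: 7 nM

In an assay on cells for agonist activity at Bombesin receptor subtype-3 (Mus musculus), read by HTRF and inositol phosphate accumulation, with a stated time of 1 h (a lower number here means that less compound is needed, a higher number that more compound is needed for the effect), compound 2 gives 25 nM, the highest number of the three. Its nearest neighbour is compound 3, which gives 7 nM, and the step of a 3.6-fold lower number from compound 2 to compound 3 (0.55 log units; beyond the scatter) lies beyond the usual scatter. Compound 1 gives 5 nM, and the step of a 5.0-fold higher number from compound 1 to compound 2 (0.70 log units; beyond the scatter) is likewise beyond the scatter. Both of these steps change the group on the saturated chain carbon bound to the aromatic nitrogen; neither touches the other end of the molecule.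

Compound 4, `CC(C)(C)Cc1cnc(CCc2ccc(-c3cccc(F)c3C(=O)O)cc2)n1CCOc1cccc(O)c1`, keeps the whole chain of compound 2 and differs only at the far end: hydrogen in place of methyl on an oxygen next to a carbonyl group. Going by the values given here, none of the measured steps alters this part of the shared core, so nothing measured here bears directly on the change. The expectation therefore rests on compound 2 alone and is uncertain in direction. A step of modest size at most is expected, which is to say a 1.2-fold higher number from compound 2 to compound 4 (0.08 log units; within the scatter). The estimate for compound 4 in this assay is 30 nM, with a range from 8 nM to 120 nM.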

Compound 4, half-maximal effective concentration: 0.8 nM
The estimate for compound 4 lay 38-fold (1.57 log units) above the measured number; measured number outside the range, below it.
By their numbers in this assay, from the lowest: compound 4; then compounds 1 and 3 (each within the scatter of the next); then compound 2.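

In this assay, replacing methoxycarbonyl with carboxy, which amounts to hydrogen in place of methyl on an oxygen next to a carbonyl group, gives a 31-fold lower number from compound 2 to compound 4 (1.49 log units; beyond the scatter). Compounds 1, 2 and 3 all carry methoxycarbonyl and differ only on the chain at the aromatic nitrogen, so they could not show how much this other end of the molecule matters; here the loss of a single carbon moves the number further than a 5.0-fold higher number from compound 1 to compound 2 (0.70 log units; beyond the scatter), the widest step among those three. No measurement here accounts for the size of this change.

Going by these compounds, only the chain of compound 2 appears in a pair with this change, so it remains open whether carboxy would give a similar step with the chains of compound 1 and compound 3. Also open, on these data alone, is how other groups in place of methoxycarbonyl, such as a primary carboxamide or an ethyl ester, would compare with the carboxy group of compound 4.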